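The source may report more compounds than this note shows. Statements on the series, on what has been measured and on what is new or still open speak of the compounds shown alone.

Measured in a functional assay on the whole organism (strain Wistar) for inhibition, with Rattus norvegicus as the target, read by paw edema, with a stated time of 3 h, at a dose of 100 mg/kg; on this read-out lower numbers stand for less inhibition and higher numbers for more inhibition at the one dose given (going by the name of the read-out):
- compound 1, `COc1cc2c(cc1OC)C(CC(=O)Nc1cccc(Cl)c1)CC2`: 24.6%
- compound 2, `COc1cc2c(cc1OC)C(CC(=O)Nc1cccc(C)c1)CC2`: 37.7%

Compound 2 stands highest of the two numbers; its nearest neighbour is compound 1, separated by a number 13.1 percentage points higher from compound 1 to compound 2 (beyond the scatter), a modest step from methyl in place of chloro on an aromatic carbon. Compound 3, `COc1ccccc1NC(=O)CC1CCc2cc(OC)c(OC)cc21`, differs from compound 2 by 2-methoxyphenyl in place of 3-methylphenyl on an amide-type nitrogen. Going by the values given here, no measured step involves an exchange of this kind on the amide-type nitrogen, so the single step from compound 1 to compound 2 bears on it only loosely. For compound 3 the expected step is a number 7.7 percentage points lower from compound 2 to compound 3 (within the scatter), not beyond the scatter in either direction. Compound 3 is therefore estimated at 30%, within 12% to 50%.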

Compound 3, a percentage reported as inhibition, in the whole organism at one dose (the size of the read-out at that dose, not a potency): 21.7%
Compound 3: the middle estimate sits 8.3 percentage points above what was measured; measured number inside the range.
By their numbers in this assay, from the lowest: compounds 3 and 1 (each within the scatter of the next); then compound 2.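

In this assay, going by these compounds alone, the exchange of the whole aryl group on the amide-type nitrogen gives a first reading of this position: 2-methoxyphenyl in place of 3-methylphenyl brings (a number 16 percentage points lower from compound 2 to compound 3 (beyond the scatter)), while 2-methoxyphenyl in place of 3-chlorophenyl brings (a number 2.9 percentage points lower from compound 1 to compound 3 (within the scatter)). Of the three compounds, then, only compound 2 stands apart, and the group carrying an oxygen does not share its higher number. Nothing available here explains this difference.

Still open, going by these compounds, is whether an amine or a carboxylic acid on the phenyl group would match compound 2. Also open, on these data alone, is how an unsubstituted phenyl would read.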